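Thiosemicarbazones on a shared core: furan-2-yl for 4-chlorophenyl

The source may hold more compounds than are shown below. What is called first, only, known or untested is meant among the compounds shown, and "the series" means these compounds.

Measured so far:
compound 1 `CC1=CC[C@H](C(C)(C)NC(=S)NN)CC1` gives 42000 nM
compound 2 `CC1=CC[C@H](C(C)(C)NC(=S)N/N=C/c2ccc(F)cc2)CC1` gives only a limit of the assay, > 100000 nM
compound 3 `CC1=CC[C@H](C(C)(C)NC(=S)N/N=C/c2ccc(Cl)cc2)CC1` gives 7800 nM

In a functional assay on NCI-H460 cells (Homo sapiens) for inhibition, read by sulforhodamine B assay, with a stated time of 48 h (on this read-out higher numbers stand for weaker inhibition of growth and lower numbers for stronger inhibition of growth), compound 3 stands lowest of the numbers shown. Its nearest neighbour is compound 1, whose number is higher than that of compound 3 by an at least 12-fold lower number from compound 2 to compound 3 (1.10 log units; beyond the scatter)-sized steps in no comparable way; compound 1 simply sits further up the scale. Compound 2 gives only a limit of the assay, > 100000 nM, as noted under (the limit of > 100000 nM in this assay, at which 1 of the 3 values shown sits).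

One step is known at the aromatic end of the hydrazone: an at least 12-fold lower number from compound 2 to compound 3 (1.10 log units; beyond the scatter), brought by chloro in place of fluoro on an aromatic carbon. It shows that this position moves the number a great deal.

Compound 4 `CC1=CC[C@H](C(C)(C)NC(=S)N/N=C/c2ccco2)CC1` differs from compound 3 by furan-2-yl in place of 4-chlorophenyl on a carbon with a double bond to nitrogen. Going by the values given here, no measured step exchanges the whole six-membered ring for a five-membered one with 1 hetero atom, so the only guide is that this end is sensitive. Among the compounds with values here, the loss of the chlorine, which was the one change that lowered the number, is expected to push compound 4 back up; the expected step is a 3.8-fold higher number from compound 3 to compound 4 (0.59 log units; beyond the scatter). Compound 4 is therefore estimated at 30000 nM, within 8000 nM to 100000 nM.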

Compound 4, concentration for 50% growth inhibition: 13500 nM
Compound 4: middle estimate off by 2.2-fold (0.35 log units), on the high side; low and high end bracket the measured number.
By their numbers in this assay, from the lowest: compounds 3 and 4 (each within the scatter of the next); then compound 1. At a limit, above all of these: compound 2.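

In this assay, furan-2-yl on a carbon with a double bond to nitrogen cannot be told apart from 4-chlorophenyl there, a 1.7-fold higher number from compound 3 to compound 4 (0.24 log units; within the scatter), so the chlorine that seemed to matter in the step from compound 2 is not required for a number in this range. The sensitivity at this end therefore looks specific to the 4-fluorophenyl of compound 2 rather than general to the ring, with an at least 7.4-fold lower number from compound 2 to compound 4 (0.86 log units; beyond the scatter), while the furan-2-yl hydrazone also improves on the free end of the core, with a 3.1-fold lower number from compound 1 to compound 4 (0.49 log units; beyond the scatter). The first of these two steps has only a lower bound on its size, since compound 2 stands at a limit of the assay and not at a number: the limit of > 100000 nM in this assay, at which 1 of the 4 values shown sits.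

The compounds shown leave open whether the ring oxygen of furan-2-yl plays any part, which thiophen-2-yl or an unsubstituted phenyl on the same carbon would test. They also leave open how 4-bromophenyl, or a ring carrying an amine or a carboxylic acid, would read in this assay, and so whether compound 2 is a lone exception.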